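Replacing the 4-Methylphenyl of Compound 2 with a Substituted Ring

The source may report more compounds than this note shows. Statements on the series, on what has been measured and on what is new or still open speak of the compounds shown alone.

Of the compounds shown here, two have been measured in an assay on isolated protein with Bile acid receptor (Homo sapiens) as the target; a higher number here means that more compound is needed for the effect, a lower number that less compound is needed. Compound 1 `CCOc1cccc(-c2ccc(CN(C(=O)C(C)C)c3cccc(/C=C/C(=O)OC)c3)cc2)c1` gives 173 nM. Compound 2 `COC(=O)/C=C/c1cccc(N(Cc2ccc(-c3ccc(C)cc3)cc2)C(=O)C(C)C)c1` gives 118 nM, the lowest of the two numbers, though the difference from compound 1 is small: a 1.5-fold lower number from compound 1 to compound 2 (0.17 log units; within the scatter). Compound 3 `COC(=O)/C=C/c1cccc(N(Cc2ccc(-c3cc(Cl)ccc3OC)cc2)C(=O)C(C)C)c1` has not yet been measured in this assay. It differs from compound 2 in one place: 5-chloro-2-methoxyphenyl in place of 4-methylphenyl on an aromatic carbon.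

Going by the values given here, only one measured step speaks to this change, the one from compound 1 to compound 2, in which one substituted phenyl group was exchanged for another at the same position without a shift beyond the scatter. That step suggests the assay tolerates variation in this distal ring, but it gives no direct reading on a chlorine atom or a methoxy group placed there. Compound 3 is therefore expected to land close to compound 2, with no step beyond the scatter: a 1.3-fold higher number from compound 2 to compound 3 (0.10 log units; within the scatter). For compound 3 the estimate in this assay is 150 nM, within a range from 55 nM to 420 nM.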

Compound 3, half-maximal effective concentration: 226 nM
For compound 3 the middle estimate is 1.5-fold (0.18 log units) below the measured one; measured number inside the range.
By their numbers in this assay, from the lowest: compounds 2, 1 and 3 (each within the scatter of the next).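

In this assay, the 5-chloro-2-methoxyphenyl group brings a chlorine atom and a hydrogen-bond acceptor to a position where 4-methylphenyl had neither, and the result is a 1.9-fold higher number from compound 2 to compound 3 (0.28 log units; within the scatter). Set against the 3-ethoxyphenyl group, the same replacement gives a 1.3-fold higher number from compound 1 to compound 3 (0.12 log units; within the scatter), so these three substituted phenyl groups, on an aromatic carbon para to a large group, cannot be told apart in this assay, even with two substituents on the ring in compound 3. Nothing further is available to explain this outcome, as no supporting measurement bears on it.

The chlorine atom and the methoxy group enter together in compound 3, so their separate contributions remain unresolved, and a ring carrying only one of them would be needed to divide them. Also open is how far this tolerance extends, for instance to an amine or a carboxylic acid on the distal ring, given that all three compounds shown carry only alkyl, alkoxy or chlorine substituents there.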